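The compounds below may be only part of what the source reports. "The series", "measured", "known", "first", "only" and "open" are said of these compounds alone.

Going by the values given here, compound 2 `Cn1cncc1C(OCc1ccc(C#N)cc1-c1cc(Cl)cc(Cl)c1)c1ccc(C#N)nc1` is the one compound of this set with a number in an assay on isolated protein (Bos taurus) for inhibition of geranylgeranyl transferase type-1 subunit beta (Homo sapiens) (on this read-out lower numbers stand for stronger inhibition and higher numbers for weaker inhibition), where compound 2 gives 960 nM. Compound 1 `Cn1cncc1C(OCc1ccc(C#N)cc1-c1cc(F)cc(F)c1)c1ccc(C#N)nc1` is reported in this assay only as a limit, > 10 nM. The step from compound 1 to compound 2, a step that the limit leaves unreadable from compound 1 to compound 2, therefore cannot be sized, because the limit of > 10 nM in this assay, at which 1 of the 2 values shown sits, sets a boundary on one of its two ends. Compound 3 `Cn1cncc1C(OCc1ccc(C#N)cc1-c1cccc(OC(F)(F)F)c1)c1ccc(C#N)nc1` has yet to be measured in this assay. It differs from compound 2 at a single position: 3-(trifluoromethoxy)phenyl in place of 3,5-dichlorophenyl on an aromatic carbon. Among the compounds with values here, no measured step in this set runs between a pair of numbers, so there is no readable precedent for exchanging one substituted phenyl for another here, and compound 3 is expected to stay near compound 2, with an expected step of a 1.0-fold higher number from compound 2 to compound 3 (0.02 log units; within the scatter) that does not clearly exceed the scatter. In this assay compound 3 is estimated at 1000 nM, within a range from 300 nM to 3500 nM.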

Compound 3, half-maximal inhibitory concentration: 990 nM
Compound 3: the middle estimate sits 1.0-fold (0.00 log units) above what was measured, within the range that was stated.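

In this assay, going by these compounds alone, the exchange of 3,5-dichlorophenyl for 3-(trifluoromethoxy)phenyl gives a 1.0-fold higher number from compound 2 to compound 3 (0.01 log units; within the scatter), the first step here that runs between two numbers. At this aromatic carbon, ortho to a large group and meta to a cyano group, the entering group brings 11 heavy atoms for 8 and 1 hydrogen-bond acceptor for 0, swapping both chlorines for a single substituent, and the read-out stays within the scatter. The step from compound 1 to compound 3 cannot be read, because compound 1 is held only as a limit: the limit of > 10 nM in this assay, at which 1 of the 3 values shown sits.

Still open, on these data alone, is how an unsubstituted phenyl would read at this position. Also open, as far as these compounds go, is what groups other than a substituted phenyl, such as an amine, a carboxylic acid or a longer alkyl chain, would do there.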